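This account rests on a few compounds, and the source may have more. Where it says the series, first, only, none or still open, it means among the compounds named here.

Measured compounds:
Compound 1 `COc1cccc(-c2ccc(OC)c(S(=O)(=O)Nc3cccc(NCCNC(=O)c4ccccc4OC)c3)c2)c1` gives 800 nM in an assay on CHO-K1 cells for agonist activity at Orexin receptor type 2 (Homo sapiens), read by a luciferase reporter; on this read-out lower numbers stand for an effect already at smaller amounts and higher numbers for an effect only at larger amounts of compound.
Compound 2 `COC(=O)c1cccc(-c2ccc(OC)c(S(=O)(=O)Nc3cccc(NCCNC(=O)c4ccccc4OC)c3)c2)c1` gives only a limit of the assay, > 10000 nM, in this assay.
Compound 3 `COc1cccc(C(=O)NCCNc2cccc(NS(=O)(=O)c3cc(-c4cccc(C(=O)N(C)C)c4)ccc3OC)c2)c1` gives 33 nM in this assay.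

Compound 3 stands at the lowest of the two numbers; compound 1 sits higher by a margin beyond the scatter, and compound 2 sits at the limit described in the limit of > 10000 nM in this assay, at which 1 of the 3 values shown sits. Compound 4 `COc1ccc(-c2cccc(C(=O)N(C)C)c2)cc1S(=O)(=O)Nc1cccc(NCCNC(=O)c2ccccc2Cl)c1` differs from compound 3 by 2-chlorophenyl in place of 3-methoxyphenyl on a carbonyl carbon. Among the measured compounds shown here, the only measured step, an at least 12-fold higher number from compound 1 to compound 2 (1.09 log units; beyond the scatter), concerns a different place in the shared core and so does not bear directly on the change at the carbonyl carbon; the pair compound 1 and compound 3 differ in two places and yield no single step. For the measured compounds named here, with no step on this position in hand, the expected change for compound 4 is small, and its number in this assay is estimated as 50 nM, ranging from 15 nM to 200 nM, which means an estimated step of a 1.5-fold higher number from compound 3 to compound 4 (0.18 log units; within the scatter).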

Compound 4, half-maximal effective concentration: 31 nM
Beside the measured number, compound 4's estimate is 1.6-fold (0.21 log units) above it; the range from low to high includes it.
By their numbers in this assay, from the lowest: compounds 4 and 3 (each within the scatter of the next); then compound 1. At a limit, above all of these: compound 2.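

In this assay, putting 2-chlorophenyl in place of 3-methoxyphenyl on a carbonyl carbon gives a 1.1-fold lower number from compound 3 to compound 4 (0.03 log units; within the scatter), which is the first step shown at this position. For this pair, the oxygen-bearing group can thus give way to a chlorine-bearing one, with the loss of one counted hydrogen-bond acceptor, and the two values stay within the scatter of each other. The compounds shown offer no evidence that would explain why this exchange leaves the number in place.

From the compounds shown here alone, only these two substituted phenyl groups are compared on this carbonyl carbon, so it remains open whether an amine or a carboxylic acid on the phenyl ring, or a cyclohexyl group in its place, would be tolerated in the same way. Going by these compounds, it also remains open whether the same exchange would read alike on the core of compound 1.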